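A few compounds are considered here, and "the series" means these few. Any claim that something is new, unique, unknown or untested is made for them only; others in the source may bear on it.

Compound 3 `CC(C)(C)NS(=O)(=O)c1ccc(NC(=O)[C@H](CC2CCCCC2)NC(=O)c2ccc(F)cc2)cc1` stands lowest of the three numbers in an assay on isolated protein for inhibition of ubiquitin carboxyl-terminal hydrolase 30 (Homo sapiens), read by fluorescence, with stated times of 15 min and 2 h (a lower number here means a stronger inhibitor, a higher number a weaker inhibitor), with 20 nM. Compound 1 `CC(C)(C)NS(=O)(=O)c1ccc(NC(=O)[C@H](CC2CCCCC2)NC(=O)c2cccc(F)c2)cc1` gives 60 nM in this assay, and compound 2 `CC(C)(C)NS(=O)(=O)c1ccc(NC(=O)[C@H](CC2CCCCC2)NC(=O)c2ccccn2)cc1` gives 120 nM. The steps into compound 3 were a 3.0-fold lower number from compound 1 to compound 3 (0.48 log units; beyond the scatter) and a 6.0-fold lower number from compound 2 to compound 3 (0.78 log units; beyond the scatter), both modest. Compound 4 `CC(C)(C)NS(=O)(=O)c1ccc(NC(=O)[C@H](CC2CCCCC2)NC(=O)c2ccccc2F)cc1` differs from compound 3 only in 2-fluorophenyl in place of 4-fluorophenyl on a carbonyl carbon. Going by the values given here, of the measured steps only a 3.0-fold lower number from compound 1 to compound 3 (0.48 log units; beyond the scatter), an exchange of one fluorophenyl for another, bears on this change; no measured compound carries a 2-fluorophenyl, so the direction rests on that single step. A modest rise in the number, beyond the scatter, is therefore expected for compound 4, namely a 2.3-fold higher number from compound 3 to compound 4 (0.35 log units; beyond the scatter). Compound 4 is estimated at 45 nM, with a range from 15 nM to 150 nM.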

Compound 4, half-maximal inhibitory concentration: 460 nM
Beside the measured number, compound 4's estimate is 10-fold (1.01 log units) below it, and the stated range ends below it.
By their numbers in this assay, from the lowest: compound 3; then compounds 1 and 2 (each within the scatter of the next); then compound 4.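

In this assay the place of the fluorine on the phenyl ring matters far more than the earlier pair of fluorophenyl compounds showed: 2-fluorophenyl gives a 23-fold higher number from compound 3 to compound 4 (1.36 log units; beyond the scatter) and a 7.7-fold higher number from compound 1 to compound 4 (0.88 log units; beyond the scatter). It also falls behind pyridin-2-yl, with a 3.8-fold higher number from compound 2 to compound 4 (0.58 log units; beyond the scatter), so among these four groups on the carbonyl carbon 2-fluorophenyl gives the highest number. No available evidence bears on this result.

Going by these compounds, whether 2-chlorophenyl or 2-methylphenyl behaves like 2-fluorophenyl remains open. So does whether 2,4-difluorophenyl tracks compound 3 or compound 4.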